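A few compounds are considered here, and "the series" means these few. Any claim that something is new, unique, unknown or untested is made for them only; others in the source may bear on it.

The compounds share the core of compound 1 `COc1cc(-c2ccnc3cc(-c4ccc(C(C)=O)cc4)nn23)cc(OC)c1OC`, which carries a 4-acetylphenyl group. In a functional assay on B16-F0 cells (Mus musculus) for inhibition, read by CCK-8 assay, with a stated time of 48 h (on this read-out lower numbers stand for stronger inhibition and higher numbers for weaker inhibition), compound 1 gives 3930 nM, the highest of the two numbers recorded, with compound 3 `COc1cc(-c2ccnc3cc(-c4ccc(-c5cnn(C)c5)cc4)nn23)cc(OC)c1OC` nearest at 1240 nM. Compound 2 `COc1cc(-c2cc3nccc(-c4c[nH]c5ccccc45)n3n2)cc(OC)c1OC` reaches only the limit of > 10000 nM in this assay, so no number is known for it. Among the measured compounds shown here, the one step between measured compounds that differ in a single place is a 3.2-fold lower number from compound 1 to compound 3 (0.50 log units; beyond the scatter), where 1-methyl-1H-pyrazol-4-yl replaces acetyl on an aromatic carbon.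

Compound 4 `COc1cc(-c2ccnc3cc(-c4ccc5cnn(C)c5c4)nn23)cc(OC)c1OC` is not yet measured. It differs from compound 1 in one place: 1-methyl-1H-indazol-6-yl in place of 4-acetylphenyl on an aromatic carbon. Like the step to compound 3, this change removes the acetyl and brings in a nitrogen-bearing aromatic ring, although here the entering group is 1-methyl-1H-indazol-6-yl rather than 1-methyl-1H-pyrazol-4-yl on a phenyl. For the measured compounds named here, the only precedent that bears on the change, the step from compound 1 to compound 3, was modest and favourable, so a modest step in the same direction is expected for compound 4 in this assay, with a wide band of uncertainty. The expected step is a 1.6-fold lower number from compound 1 to compound 4 (0.20 log units; within the scatter). Compound 4 is therefore estimated at 2500 nM, with a range from 800 nM to 8000 nM.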

Compound 4, half-maximal inhibitory concentration: 1000 nM
Compound 4: middle estimate off by 2.5-fold (0.40 log units), on the high side, within the range that was stated.
By their numbers in this assay, from the lowest: compounds 4 and 3 (each within the scatter of the next); then compound 1. At a limit, above all of these: compound 2.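

Compound 3 had kept the phenyl ring and changed only what it carried, whereas compound 4 gives up the whole 4-acetylphenyl group for the fused 1-methyl-1H-indazol-6-yl, and in this assay this brings a 3.9-fold lower number from compound 1 to compound 4 (0.59 log units; beyond the scatter). The result shows that this place, on an aromatic carbon of the shared core, does not depend on keeping a 4-substituted phenyl group or the acetyl carbonyl, since a ring system with no carbonyl and two nitrogen atoms serves there as well. The two replacements also end up level: compound 3 gives 1240 nM and compound 4 gives 1000 nM, values within the scatter of each other, so the fused ring and the phenyl bearing 1-methyl-1H-pyrazol-4-yl cannot be told apart in this read-out.

Still open, on these data alone, is whether an amine or a carboxylic acid on the 1-methyl-1H-indazol-6-yl group, or a longer chain in place of its methyl, would shift the number further in this assay. Nothing among the data shown bears on why the step from the acetyl compound occurs.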